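Methoxy to Hydroxy: What to Expect for Compound 4

This account rests on a few compounds, and the source may have more. Where it says the series, first, only, none or still open, it means among the compounds named here.

Of the compounds shown here, three sharing one core have been tested in a functional assay on Ehrlich cells (Mus musculus) for cytotoxicity, tested at 10 ug/mL; on this read-out lower numbers stand for a weaker effect and higher numbers for a stronger effect at the one concentration tested. Compound 1 `COc1cc(N2C(N)=C(C#N)C(c3c(O)ccc4ccccc34)C3=C2CC(C)(C)CC3=O)cc(OC)c1OC` gives 2%. Compound 2 `COc1ccccc1C1C(C#N)=C(N)N(c2cc(OC)c(OC)c(OC)c2)C2=C1C(=O)CC(C)(C)C2` gives 30%. Compound 3 `COc1cc(N2C(N)=C(C#N)C(c3ccc(Cl)cc3Cl)C3=C2CC(C)(C)CC3=O)cc(OC)c1OC` gives 20%. Compound 2 stands highest of the three numbers: the steps of a number 28 percentage points higher from compound 1 to compound 2 (beyond the scatter) and a number 18 percentage points higher from compound 1 to compound 3 (beyond the scatter) lie beyond the scatter, whereas a number 10 percentage points lower from compound 2 to compound 3 (within the scatter) stays within it, so compound 2 and compound 3 cannot be told apart.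

Compound 4 `COc1cc(N2C(N)=C(C#N)C(c3ccccc3O)C3=C2CC(C)(C)CC3=O)cc(OC)c1OC` differs from compound 2 in one place: hydrogen in place of methyl on an oxygen on an aromatic ring. For the measured compounds named here, no measured step changes just this group; the steps known all exchange the whole group on the saturated ring carbon, and each was modest. Compound 1, whose 2-hydroxynaphthalen-1-yl group also carries a hydroxy, gave the low 2%, but its larger ring system makes that a weak guide. A small step down, or none beyond the scatter, is therefore expected, a number 10 percentage points lower from compound 2 to compound 4 (within the scatter). Compound 4 is estimated at 20%, within 5% to 35%.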

Compound 4, a percentage reported as activity, at one concentration (the size of the read-out at that concentration, not a potency): 0%
Compound 4: the middle estimate sits 20 percentage points above what was measured, and the stated range ends above it.
By their numbers in this assay, from the lowest: compounds 4 and 1 (each within the scatter of the next); then compounds 3 and 2 (each within the scatter of the next).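

For the compounds shown here, changing methoxy to hydroxy on an oxygen on an aromatic ring is the first change here made at that oxygen alone, and in this assay it removes the effect seen for compound 2, with a number 30 percentage points lower from compound 2 to compound 4 (beyond the scatter). The 2-hydroxyphenyl group also falls short of the 2,4-dichlorophenyl group, with a number 20 percentage points lower from compound 3 to compound 4 (beyond the scatter), yet it cannot be told apart from the 2-hydroxynaphthalen-1-yl group, with a number 2 percentage points lower from compound 1 to compound 4 (within the scatter), so among these four compounds the two carrying a hydroxy sit low. Nothing measured here explains this drop.

Still open, from the compounds shown here alone, is whether the loss belongs to the hydroxy specifically or to any replacement of methoxy; a 2-ethoxyphenyl or 2-aminophenyl group on the same saturated ring carbon would help separate these. Going by these compounds, with one concentration tested, potency also remains unknown.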